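Ring Size of the Basic Amine on the Indole Nitrogen

The source may hold more compounds than are shown below. What is called first, only, known or untested is meant among the compounds shown, and "the series" means these compounds.

Measured so far:
Compound 1 `CN1CCC(n2cc(S(=O)(=O)c3cccc4ccccc34)c3ccccc32)C1`: 60 nM
Compound 2 `CN1CCC(n2cc(S(=O)(=O)c3cccc4cccnc34)c3ccccc32)C1`: 76 nM
Compound 3 `O=S(=O)(c1cccc(F)c1)c1cn(C2CCCNC2)c2ccc(F)cc12`: 18 nM

All three were run in a functional assay on HeLa cells for antagonist activity at 5-hydroxytryptamine receptor 6 (Homo sapiens), read by cAMP accumulation and immunoassay, with a stated time of 10 min; on this read-out higher numbers stand for weaker inhibition and lower numbers for stronger inhibition. Compound 1 stands second highest of the three numbers; compound 2 lies within the scatter of it, while compound 3 sits clearly lower, beyond the scatter. Compound 3 differs from compound 1 in several places at once, so no single change can be read from that gap.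

Compound 4 `CN1CCCC(n2cc(S(=O)(=O)c3cccc4ccccc34)c3ccccc32)C1` has not been measured. It differs from compound 1 by 1-methylpiperidin-3-yl in place of 1-methylpyrrolidin-3-yl on an aromatic nitrogen. Among the measured compounds shown here, no measured pair shows this change on its own. The expected step in this assay from compound 1 to compound 4 is small, likely within the scatter, with no firm direction; an estimated step of a 1.2-fold lower number from compound 1 to compound 4 (0.08 log units; within the scatter) is taken. Compound 4 is therefore expected to give about 50 nM, within a range of 20 nM to 150 nM.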

Compound 4, half-maximal inhibitory concentration: 107 nM
Compound 4: middle estimate off by 2.1-fold (0.33 log units), on the low side; the range from low to high includes it.
By their numbers in this assay, from the lowest: compound 3; then compounds 1, 2 and 4 (each within the scatter of the next).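

Among the compounds shown here, the first single-change pair at this aromatic nitrogen gives, in this assay, a 1.8-fold higher number from compound 1 to compound 4 (0.25 log units; within the scatter). Going from the five-membered to the six-membered ring therefore yields no step that stands clear of the scatter, and the position accepts either ring on the core of compound 1. No evidence on hand bears on this step.

Left open is whether an azetidine ring or an open-chain dimethylaminoethyl group on this nitrogen would stay in the same range. Also open, as far as these compounds go, is whether the ring-size result carries over to the cores of compound 2 and compound 3.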